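Series notes: from compound 2 to compound 4

The compounds below may be only part of what the source reports. "The series", "measured", "known", "first", "only" and "open" are said of these compounds alone.

Measured so far:
compound 1 `NC(=O)Nc1sc(-c2ccc(C(=O)N3CCCCC3)cc2)cc1C(=O)N[C@H]1CCCNC1` — 10800 nM
compound 2 `NC(=O)Nc1sc(-c2ccc(C(=O)N3CCOCC3)cc2)cc1C(=O)N[C@H]1CCCNC1` — "not determined" (no result reported)
compound 3 `NC(=O)Nc1sc(-c2ccc(C(N)=O)cc2)cc1C(=O)N[C@H]1CCCNC1` — "not determined" (no result reported)

In an assay on isolated protein for inhibition of cyclin-dependent kinase 2-associated protein 1 (Homo sapiens) (a lower number here means a stronger inhibitor, a higher number a weaker inhibitor), compound 1 gives 10800 nM, the only numerical result in this set. In this assay compound 2 gives "not determined" (no result reported). In this assay compound 3 likewise gives "not determined" (no result reported). Compound 2 therefore stands without a number of its own; the one figure available for the shared core, from compound 1, is weak.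

Compound 4 `CN(C)c1ccc(-c2cc(C(=O)N[C@H]3CCCNC3)c(NC(N)=O)s2)cc1` is the next member. Relative to compound 2 the change is dimethylamino in place of (morpholin-4-yl)carbonyl on an aromatic carbon. Within the data shown here, no step between measured compounds exists to calibrate this change, so its size in this assay can only be guessed; the expectation is a modest shift in either direction, not clearly beyond the scatter, with the weak result of compound 1 as the sole anchor for the level.

Compound 4 is expected to give about 8000 nM in this assay, estimated within 2000 nM to 30000 nM.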

Compound 4, half-maximal inhibitory concentration: 8400 nM
Compound 4: middle estimate off by 1.1-fold (0.02 log units), on the low side; low and high end bracket the measured number.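

In this assay, among these compounds, the exchange of (piperidin-1-yl)carbonyl for dimethylamino on an aromatic carbon gives a 1.3-fold lower number from compound 1 to compound 4 (0.11 log units; within the scatter) and is the first calibrated change at this position. On the shared core, a group on this carbon, para to a large group, can therefore lack both carbonyl and ring with the two compounds reading at one weak level. The step from compound 2 to compound 4 cannot be read, so the morpholine amide adds nothing to this comparison.

No measured data at hand account for this result. Open, going by these compounds, is whether a carboxylic acid or an aminomethyl group on this aromatic carbon would move the number beyond the scatter, or whether this position simply has little bearing on the level.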